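Methoxy to Fluoro on the Shared Core: Predicting Cytotoxicity

This account rests on a few compounds, and the source may have more. Where it says the series, first, only, none or still open, it means among the compounds named here.

Compound 1 `CCS(=O)(=O)Nc1ccc(NC(=O)c2ccc(C#N)cc2)cc1OC` in an ADME assay on RAW264.7 cells (Mus musculus) for cytotoxicity, read by MTT assay, with a stated time of 48 h (on this read-out lower numbers stand for stronger inhibition and higher numbers for weaker inhibition), gives 66400 nM.
Compound 2 `COc1cc(NC(=O)c2ccc(C#N)cc2)ccc1NS(=O)(=O)C(F)(F)F` in this assay gives only a limit, > 250000 nM.

Two compounds share one core and differ only in the group on the sulfonyl sulfur. Compound 2 stands at the limit of the assay, (the limit of > 250000 nM in this assay, at which 1 of the 2 values shown sits), so no number is known for it, only that it is weaker than compound 1. For the measured compounds named here, the single measured step, an at least 3.7-fold higher number from compound 1 to compound 2 (0.57 log units; beyond the scatter), concerns trifluoromethyl in place of ethyl on that sulfur, a different place from the change now in question.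

Compound 3 `N#Cc1ccc(C(=O)Nc2ccc(NS(=O)(=O)C(F)(F)F)c(F)c2)cc1` differs from compound 2 by fluoro in place of methoxy on an aromatic carbon. No measured step touches this position, so nothing shown here says how such a swap moves the read-out. Going by the values given here, the only anchor is that compound 2 already sits at the limit of the assay. Compound 3 is therefore expected to give 250000 nM, with a range from 70000 nM to 900000 nM. Against compound 2 this expectation means a step of a number no higher from compound 2 to compound 3 (the limit leaves the size open), that is, no step beyond the scatter is expected, and a second limit is quite likely.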

Compound 3, half-maximal inhibitory concentration: > 250000 nM
Compound 3: no number, only a limit; the forecaster's own chance of this, stated with the estimate: 55%; the middle value lies on the limit itself.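

Compound 2 and compound 3 both end at a limit of the assay rather than at a number, so no step can be read for fluoro in place of methoxy: the limit of > 250000 nM in this assay, at which 2 of the 3 values shown sit.

The compounds shown leave open whether this swap moves the read-out in this assay at all, and if so, in which direction and how far.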